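The source may hold more compounds than are shown below. What is called first, only, known or untested is meant among the compounds shown, and "the series" means these compounds.

Working notes on the series. In a functional assay on MCF7 cells (Homo sapiens) for antiproliferative activity, read by sulforhodamine B assay, with a stated time of 48 h (a lower number here means a stronger inhibitor, a higher number a weaker inhibitor), compound 1 `O=C1NCCN1c1ccc(S(=O)(=O)Nc2ccc(C3CCCCC3)cc2)cc1` gives > 1000 nM, which is a limit of the assay and not a number. Compound 2 `O=C1NCCN1c1ccc(S(=O)(=O)Nc2ccc(F)cc2)cc1` gives 690 nM. For the measured compounds named here, compound 3 `Cc1ccc(NS(=O)(=O)c2ccc(N3CCNC3=O)cc2)cc1C` gives 230 nM, the lower of the two actual numbers so far.

The next structure is compound 4 `CCc1ccc(NS(=O)(=O)c2ccc(N3CCNC3=O)cc2)cc1`, with 4-ethylphenyl in place of 3,4-dimethylphenyl on a sulfonamide nitrogen.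

Going by the values given here, two measured steps bear on this. The first starts from the limit and shows an at least 1.4-fold lower number from compound 1 to compound 2 (0.16 log units; that floor lies within the scatter), so it gives no firm size. Among the compounds with values here, the second shows a 3.0-fold lower number from compound 2 to compound 3 (0.48 log units; beyond the scatter), a modest change on the same sulfonamide nitrogen, and it is the only firm guide. A change larger than that modest one is not expected here, and a small drift towards a higher number is the likeliest outcome. The expected step is a 1.3-fold higher number from compound 3 to compound 4 (0.12 log units; within the scatter), not beyond the scatter. Compound 4 is estimated at 300 nM, with an expected range of 110 nM to 800 nM.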

Compound 4, half-maximal inhibitory concentration: 810 nM
Estimate against measurement, compound 4: 2.7-fold (0.43 log units) below; the measured number lies above the stated range.
By their numbers in this assay, from the lowest: compound 3; then compounds 2 and 4 (each within the scatter of the next). At a limit, above all of these: compound 1.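

In this assay, for the compounds shown here, a 3.5-fold higher number from compound 3 to compound 4 (0.55 log units; beyond the scatter) is beyond the scatter, although 3,4-dimethylphenyl and 4-ethylphenyl hold the same atoms joined differently, so this position on the sulfonamide nitrogen answers to how the carbons are arranged and not only to how many there are, which the earlier steps could not show. With a 1.2-fold higher number from compound 2 to compound 4 (0.07 log units; within the scatter), within the scatter, ethyl and fluoro on that aromatic carbon are not told apart. The remaining step, an at least 1.2-fold lower number from compound 1 to compound 4 (0.09 log units; that floor lies within the scatter), starts from a limit and gives no firm size: the limit of > 1000 nM in this assay, at which 1 of the 4 values shown sits.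

Still open, going by these compounds, is whether a single methyl on the phenyl ring would hold the number of compound 3 or whether both methyl groups are needed. The compounds shown also leave open how an amine or a carboxylic acid on that ring would read.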